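A few compounds are considered here, and "the series" means these few. Any claim that something is new, unique, unknown or untested is made for them only; others in the source may bear on it.

Measured so far in a functional assay on HepG2 cells (Homo sapiens) for inhibition, read by MTT assay, with a stated time of 24 h; on this read-out lower numbers stand for stronger inhibition and higher numbers for weaker inhibition:
compound 1 `CC1(C)[C@H]2CC[C@]1(C)N(Cc1cn(-c3ccc(Cl)cc3)nn1)C(=O)C2` — 90 nM
compound 2 `COc1ccc(-n2cc(CN3C(=O)C[C@@H]4CC[C@@]3(C)C4(C)C)nn2)cc1` — 100 nM
compound 3 `Cc1ccc(-n2cc(CN3C(=O)C[C@@H]4CC[C@@]3(C)C4(C)C)nn2)cc1` — 480 nM

Compound 1 gives the lowest of the three numbers in this assay. Compound 2 lies within the scatter of it, a 1.1-fold higher number from compound 1 to compound 2 (0.05 log units; within the scatter), while compound 3 lies beyond it, a 5.3-fold higher number from compound 1 to compound 3 (0.73 log units; beyond the scatter); compound 2 and compound 3 are likewise separated, a 4.8-fold higher number from compound 2 to compound 3 (0.68 log units; beyond the scatter). The shared core is unchanged across the set; the three differ only in the group carried on the aromatic nitrogen.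

Compound 4 `CC1(C)[C@H]2CC[C@]1(C)N(Cc1cn(-c3ccccc3C#N)nn1)C(=O)C2` is the next case. Change from compound 1: 2-cyanophenyl in place of 4-chlorophenyl on an aromatic nitrogen. Among the measured compounds shown here, no measured step matches this change. Each measured step exchanges one substituent for another on the phenyl; the present change replaces the whole 4-chlorophenyl with 2-cyanophenyl, and a nitrile has not been tried in this series. What the measured steps do show is that altering the phenyl can leave the number where it is, a 1.1-fold higher number from compound 1 to compound 2 (0.05 log units; within the scatter), or raise it modestly, a 5.3-fold higher number from compound 1 to compound 3 (0.73 log units; beyond the scatter). For the measured compounds named here, no step in this set lowers the number beyond the scatter. For compound 4 a somewhat higher number in this assay is therefore expected, a 2.8-fold higher number from compound 1 to compound 4 (0.44 log units; beyond the scatter), with wide uncertainty. The estimated value for compound 4 is 250 nM, in the range 80 nM to 900 nM.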

Compound 4, half-maximal inhibitory concentration: 180 nM
For compound 4 the middle estimate is 1.4-fold (0.14 log units) above the measured one; measured number inside the range.
By their numbers in this assay, from the lowest: compounds 1, 2 and 4 (each within the scatter of the next); then compound 3.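

In this assay, 2-cyanophenyl on the aromatic nitrogen stays within the scatter of 4-chlorophenyl (a 2.0-fold higher number from compound 1 to compound 4 (0.30 log units; within the scatter)) and of 4-methoxyphenyl (a 1.8-fold higher number from compound 2 to compound 4 (0.26 log units; within the scatter)), so a group carrying a nitrile joins these two, and the set now holds a group other than a 4-substituted phenyl that stays within the scatter of both. Against 4-methylphenyl the same group gives a lower number beyond the scatter (a 2.7-fold lower number from compound 3 to compound 4 (0.43 log units; beyond the scatter)), which leaves compound 3 as the only one of the four separated from all the others, with the highest number in the set; compounds 1, 2 and 4 cannot be ordered among themselves. Nothing available explains these numbers or connects them to any property of the groups.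

The compounds shown leave open whether the result for compound 4 belongs to the nitrile or to its place on the phenyl, a question that 4-cyanophenyl and 2-chlorophenyl would address. They also leave open how this position responds to a phenyl bearing an amine or a carboxylic acid, or to a longer alkyl chain in place of the phenyl.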